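This account rests on a few compounds, and the source may have more. Where it says the series, first, only, none or still open, it means among the compounds named here.

Compound 1 `CC1=C(C(=O)OC(C)(C)C)C(c2cccs2)NC(=O)N1`: 38% in an assay on membranes from HEK293 cells for displacement of a labelled ligand from adenosine receptor A2b (Homo sapiens), read by scintillation counting, with a stated time of 30 min, tested at 1 uM; a higher number here means more inhibition at the concentration tested (going by the name of the read-out), a lower number less inhibition
Compound 2 `CC1=C(C(=O)NC(C)C)C(c2cccs2)NC(=O)N1`: 40%
Compound 3 `CCC(CC)OC(=O)C1=C(C)NC(=O)NC1c1ccco1`: 35%

Compound 3 lies within the usual scatter of both compound 1 and compound 2, so the three numbers cannot be told apart. Going by the values given here, the only measured step, a number 2 percentage points higher from compound 1 to compound 2 (within the scatter), concerns the group on the carbonyl carbon and leaves the aromatic ring untouched, so it does not bear on the change considered here. Compound 4 `CCC(CC)OC(=O)C1=C(C)NC(=O)NC1c1cccs1` differs from compound 3 by thiophen-2-yl in place of furan-2-yl on a saturated ring carbon. Compound 1 and compound 2 already carry thiophen-2-yl while compound 3 carries furan-2-yl, and their values sit within the scatter of each other, although the ester group differs as well. No step beyond the scatter is therefore expected in this assay. Compound 4 is estimated at 38%, with a range from 25% to 51%. This estimate means an expected step of a number 3 percentage points higher from compound 3 to compound 4 (within the scatter).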

Compound 4, a percentage reported as inhibition, at one concentration (the size of the read-out at that concentration, not a potency): 6%
Compound 4: the middle estimate sits 32 percentage points above what was measured; measured number outside the range, below it.
By their numbers in this assay, from the lowest: compound 4; then compounds 3, 1 and 2 (each within the scatter of the next).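

In this assay, swapping the ring oxygen of furan-2-yl for the sulfur of thiophen-2-yl, with the heavy-atom count unchanged, is far from neutral next to the (pentan-3-yl)oxy group (a number 29 percentage points lower from compound 3 to compound 4 (beyond the scatter)). With thiophen-2-yl held constant, the group on the carbonyl carbon matters as well (a number 32 percentage points lower from compound 1 to compound 4 (beyond the scatter); a number 34 percentage points lower from compound 2 to compound 4 (beyond the scatter)), so among these compounds thiophen-2-yl goes with a low number only in this pairing. No measurement shown explains this drop.

From the compounds shown here alone, whether furan-2-yl would keep its number beside tert-butoxy or isopropylamino remains open. So does the outcome for a phenyl ring on the saturated ring carbon.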